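Exchanging the 1H-benzimidazol-5-yl group of compound 2

A few compounds are considered here, and "the series" means these few. Any claim that something is new, unique, unknown or untested is made for them only; others in the source may bear on it.

In a functional assay on K562 cells (Homo sapiens) for inhibition, read by trypan blue exclusion, with a stated time of 72 h (a higher number here means a weaker inhibitor, a lower number a stronger inhibitor), compound 1 (`Cn1c(=O)c(S(=O)(=O)c2ccccc2)cc2cnc(Nc3cnc4[nH]ccc4c3)nc21`) gives 5000 nM and compound 2 (`Cn1c(=O)c(S(=O)(=O)c2ccc(F)cc2)cc2cnc(Nc3ccc4[nH]cnc4c3)nc21`) gives 10000 nM. Among the compounds with values here, these two values lie within the scatter of each other, so compound 2 stands level with compound 1 on the numbers so far. Compound 3 (`Cn1c(=O)c(S(=O)(=O)c2ccc(F)cc2)cc2cnc(Nc3cnc4[nH]ccc4c3)nc21`) has not yet been measured. It differs from compound 2 in one place, where the 1H-benzimidazol-5-yl group leaves: a group of 9 heavy atoms (7 carbon, 2 nitrogen; one five-membered aromatic ring with 1 hetero atom, one six-membered aromatic ring with 1 hetero atom) in place of a group of 9 heavy atoms (7 carbon, 2 nitrogen; one five-membered aromatic ring with 2 hetero atoms, one six-membered aromatic ring of carbon only), on a nitrogen on an aromatic ring. Within the data shown here, no pair of measured compounds shows what an exchange like this does in this assay, so any forecast is loose. Among the measured compounds shown here, the only guide is the narrow spread of the two known values, from compound 1 at 5000 nM to compound 2 at 10000 nM. The expected result is a 1.7-fold lower number from compound 2 to compound 3 (0.22 log units; within the scatter), an estimated step that stays within the scatter. Compound 3 is estimated at 6000 nM, with an expected range of 2500 nM to 15000 nM.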

Compound 3, half-maximal inhibitory concentration: 750 nM
The estimate for compound 3 lay 8.0-fold (0.90 log units) above the measured number; measured number outside the range, below it.
By their numbers in this assay, from the lowest: compound 3; then compounds 1 and 2 (each within the scatter of the next).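

In this assay, the exchange on the nitrogen gives a 13-fold lower number from compound 2 to compound 3 (1.12 log units; beyond the scatter), although the group that leaves and the group that enters hold the same heavy atoms, hydrogen-bond donors and acceptors and no net charge, so at this place the way the same atoms are joined into two rings matters, not only what they are. The second step shows that the other end of the molecule counts too: fluoro in place of hydrogen on an aromatic carbon gives a 6.7-fold lower number from compound 1 to compound 3 (0.82 log units; beyond the scatter). No measurement shown here explains either step.

Going by these compounds, whether fluoro has a similar effect alongside the 1H-benzimidazol-5-yl group remains open. So does the outcome of chloro or methoxy on that aromatic carbon, or of a 1H-indol-5-yl group on the nitrogen.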